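Replacing 1-chloroethenyl in compound 2: notes on compound 4

The source may report more compounds than this note shows. Statements on the series, on what has been measured and on what is new or still open speak of the compounds shown alone.

Measured in an ADME assay on L1210/0 cells (Mus musculus) for cytotoxicity, with a stated time of 48 h; a lower number here means a stronger inhibitor, a higher number a weaker inhibitor
compound 1 `CC(=O)OC(C)Cn1cnc2c(=S)[nH]c(N)nc21` gives 128000 nM
compound 2 `C=C(Cl)c1cn([C@H]2C[C@H](O)[C@@H](CO)O2)c(=O)[nH]c1=O` gives 1660 nM
compound 3 `CC1(C)C(CO)CC1Cn1nnc2c(N)nc(N)nc21` gives > 200000 nM (a limit)

Compound 2, at 1660 nM, has the lower of the two true numbers in this assay. The nearest, compound 1 at 128000 nM, lies beyond the scatter from it. Compound 3 stands at > 200000 nM, which is a limit and not a number.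

Compound 4 `C[S+]([O-])c1cn([C@H]2C[C@H](O)[C@@H](CO)O2)c(=O)[nH]c1=O` keeps the rest of compound 2 and changes one group, on an aromatic carbon: a group of 3 heavy atoms (1 carbon, 1 oxygen, 1 sulfur; no ring) in place of a group of 3 heavy atoms (2 carbon, 1 chlorine; no ring), on an aromatic carbon. The 1-chloroethenyl group leaves, and the group that enters adds a hydrogen-bond acceptor. Among the measured compounds shown here, no measured pair differs in one place, so the size of this change has no direct precedent. A step to a higher number, meaning a weaker inhibitor, beyond the scatter is expected, given the low position of compound 2 at 1660 nM. The expected change is a 24-fold higher number from compound 2 to compound 4 (1.38 log units; beyond the scatter). For compound 4 the estimated value is 40000 nM, with an expected range of 6000 nM to 200000 nM.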

Compound 4, half-maximal inhibitory concentration: > 200000 nM
Compound 4: a limit, no number (the forecaster's own chance of this, stated with the estimate: 30%); at least 5.0-fold (0.69 log units) between middle value and limit.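

In this assay, among the compounds shown here, this aromatic carbon gives the first readable step, an at least 120-fold higher number from compound 2 to compound 4 (2.08 log units; beyond the scatter), so the group held here is not indifferent to the read-out. Both groups have the same count of heavy atoms, so that count alone does not preserve the value of compound 2, and the change also adds a hydrogen-bond acceptor. Compound 4 gives > 200000 nM, which is a limit, so the step sets only a lower bound on the loss and its full size cannot be read: the limit of > 200000 nM in this assay, at which 2 of the 4 values shown sit.

The compounds shown cannot separate the loss of the 1-chloroethenyl group from the entry of the sulfur-bearing group with its acceptor. From the compounds shown here alone, whether a plain ethenyl, a single chlorine or an amine at this carbon would stay near compound 2 remains open.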